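Urea in Place of Amide on a Scaffold Without Measurable Toxicity

The compounds below may be only part of what the source reports. "The series", "measured", "known", "first", "only" and "open" are said of these compounds alone.

The account concerns two measured compounds and one not yet tested. Compound 1 `O=C(Nc1cccc(-n2cc(-c3ccncc3)c(-c3ccc(Cl)c(O)c3)n2)c1)Nc1cccc(C(F)(F)F)c1` was examined in a functional assay on MDA-MB-231 cells (Homo sapiens) for inhibition, read by sulforhodamine B assay, with a stated time of 48 h; on this read-out lower numbers stand for higher toxicity in this test and higher numbers for lower toxicity in this test. In this assay compound 1 reached only the limit of > 32500 nM, which is a limit of the test and not a number. Compound 2 `COc1cc(-c2nn(-c3cccc(NC(=O)c4cccc(C(F)(F)F)c4)c3)cc2-c2ccncc2)ccc1Cl` stands in the same place: in this assay compound 2 gave only the limit > 50000 nM. Both results are limits the limit of > 32500 nM in this assay, at which 1 of the 2 values shown sits (the limit of > 50000 nM in this assay, at which 1 of the 2 values shown sits), so neither compound shows measurable toxicity toward these cells within the tested range.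

Compound 3 `COc1cc(-c2nn(-c3cccc(NC(=O)Nc4cccc(C(F)(F)F)c4)c3)cc2-c2ccncc2)ccc1Cl` differs from compound 2 by (3-(trifluoromethyl)phenyl)amino in place of 3-(trifluoromethyl)phenyl on a carbonyl carbon. Among the measured compounds shown here, no measured pair isolates this change. Compound 1 carries this same urea linkage and sits at the limit > 32500 nM. The writer therefore expects no step beyond the scatter, a number no higher from compound 2 to compound 3 (the limit leaves the size open). Compound 3 is estimated at 50000 nM, between 20000 nM and 120000 nM, most probably reported again only as a limit.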

Compound 3, concentration lethal to 50% of the cells: 25500 nM
Beside the measured number, compound 3's estimate is 2.0-fold (0.29 log units) above it; low and high end bracket the measured number.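

Among the compounds shown here, compound 3 is the only one of the three compounds with a number rather than a limit in this assay, so this urea with a methyl on the oxygen brings the read-out within the range of the test. At the carbonyl carbon, (3-(trifluoromethyl)phenyl)amino in place of 3-(trifluoromethyl)phenyl gives an at least 1.9-fold lower number from compound 2 to compound 3 (0.29 log units; that floor lies within the scatter), while methyl in place of hydrogen on an oxygen on an aromatic ring, with the urea kept, gives an at least 1.2-fold lower number from compound 1 to compound 3 (0.10 log units; that floor lies within the scatter). The first of these floors rests on compound 2, whose value is a limit and not a number: the limit of > 50000 nM in this assay, at which 1 of the 3 values shown sits.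

From the compounds shown here alone, the true size of the second step also stays open, since compound 1 too stands at a limit: the limit of > 32500 nM in this assay, at which 1 of the 3 values shown sits. The compounds shown further leave open what an ethyl group on that oxygen or a carboxylic acid in place of the trifluoromethyl would do to the number.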